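A few compounds are considered here, and "the series" means these few. Any claim that something is new, unique, unknown or untested is made for them only; others in the source may bear on it.

In a functional assay on MCF-A cells (Homo sapiens) for cytotoxicity (on this read-out higher numbers stand for weaker inhibition of growth and lower numbers for stronger inhibition of growth), compound 1 (`CSc1ccc(C2=C(c3ccc(F)c(F)c3)C(=O)N3CCCC3C2)cc1`) gives 800 nM. Compound 2 (`COc1ccc(C2=C(c3ccc(SC)cc3)CC3CCCN3C2=O)cc1OC`) gives 600 nM, which lies within the scatter of the number for compound 1. Compound 3 (`CSc1ccc(C2=C(c3ccc(O)c(O)c3)C(=O)N3CCCC3C2)cc1`) gives 80000 nM, so compound 1 sits far from it and close to compound 2.

Compound 4 (`CSc1ccc(C2=C(c3ccc(C)cc3)C(=O)N3CCCC3C2)cc1`) keeps the core of compound 1 and carries 4-methylphenyl in place of 3,4-difluorophenyl on a double-bonded ring carbon. For the measured compounds named here, only one measured step bears on this place, the change to 3,4-dihydroxyphenyl, and it is large: a 100-fold higher number from compound 1 to compound 3 (2.00 log units; beyond the scatter). Going by the values given here, that shows the group here can matter a great deal, but no measured compound carries 4-methylphenyl, so the size of that step cannot simply be carried over. No step beyond the scatter is therefore expected in this assay, and no direction can be favoured with confidence. The expected change is small, and the estimate is a 1.1-fold lower number from compound 1 to compound 4 (0.06 log units; within the scatter). For compound 4 the estimated value is 700 nM, with an expected range from 200 nM to 2500 nM.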

Compound 4, concentration for 50% growth inhibition: 600 nM
Estimate against measurement, compound 4: 1.2-fold (0.07 log units) above; measured number inside the range.
By their numbers in this assay, from the lowest: compounds 2, 4 and 1 (each within the scatter of the next); then compound 3.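

In this assay, the step of a 1.3-fold lower number from compound 1 to compound 4 (0.12 log units; within the scatter) shows that this place on the double-bonded ring carbon can hold either 3,4-difluorophenyl or 4-methylphenyl with no difference beyond the scatter. The large step seen earlier is therefore not a general result of replacing 3,4-difluorophenyl: the step of a 130-fold lower number from compound 3 to compound 4 (2.12 log units; beyond the scatter) sets compound 3 apart from compound 4 as well, so among these three groups, only 3,4-dihydroxyphenyl stands out. Nothing measured here explains why compound 3 stands apart.

On these data alone, it remains open whether a single hydroxy group, as in 4-hydroxyphenyl, would give a number close to that of compound 3 or close to that of compound 4. As far as these compounds go, how an aminophenyl or carboxyphenyl group would read at this place also remains open.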